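The compounds below may be only part of what the source reports. "The series", "measured", "known", "first", "only" and "open" are said of these compounds alone.

Measured compounds:
- compound 1 `O=C(CCC1=CCCN(Cc2ccc(F)cc2)C1=O)NO`: in a functional assay on PC-3 cells (Homo sapiens) for inhibition, read by sulforhodamine B assay (a lower number here means a stronger inhibitor of growth, a higher number a weaker inhibitor of growth), compound 1 gives "not determined" (no result reported)
- compound 2 `O=C(CCC1=CCCN(Cc2ccc([N+](=O)[O-])cc2)C1=O)NO`: in this assay compound 2 gives 3010 nM
- compound 3 `Cc1ccc(CN2CCC=C(CCC(=O)NO)C2=O)cc1`: in this assay compound 3 gives 8100 nM

Within the data shown here, compound 3 stands at the highest of the two numbers reported in this assay; the only measured step, a 2.7-fold higher number from compound 2 to compound 3 (0.43 log units; beyond the scatter), separates it from compound 2, and compound 1 gave no result.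

Compound 4 `O=C(CCC1=CCCN(Cc2ccc(NC(=O)c3ccccc3)cc2)C1=O)NO` differs from compound 3 in one place: benzamido in place of methyl on an aromatic carbon.

Among the measured compounds shown here, only the single step to compound 3 bears on this change. It shows that exchanging the group at this position moves the number modestly, beyond the scatter, but neither measured compound carries benzamido, so the direction for compound 4 is not fixed by the data. The expectation is a step of similar size, with the number for compound 4 falling below that of compound 3, as a 3.2-fold lower number from compound 3 to compound 4 (0.51 log units; beyond the scatter), but with a wide range.

Compound 4 is estimated to give 2500 nM in this assay, within 600 nM to 10000 nM.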

Compound 4, concentration for 50% growth inhibition: > 10000 nM
Compound 4 gave a limit, no number; the forecaster's own chance of this, stated with the estimate: 10%; middle value at least 4.0-fold (0.60 log units) away from the limit.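

Compound 4 returns only a limit in this assay, not a number: > 10000 nM. Benzamido, with its extra aromatic ring and amide hydrogen, gives no gain at this aromatic carbon over nitro, as an at least 3.3-fold higher number from compound 2 to compound 4 (0.52 log units; beyond the scatter) shows, while the comparison with methyl stays unsettled, since an at least 1.2-fold higher number from compound 3 to compound 4 (0.09 log units; that floor lies within the scatter) gives only a floor. The upper end of the measurable range is thus reached by a change at this position alone: the limit of > 10000 nM in this assay, at which 1 of the 4 values shown sits.

On these data alone, how far compound 4 lies past its limit remains open, and so does any placing of the fluoro group of compound 1, which has no result. Also open, as far as these compounds go, is whether an amine or a carboxylic acid on the same aromatic carbon would give a number lower than that of compound 2.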